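Swapping Hydroxy for Methyl on the Shared Core

The source may report more compounds than this note shows. Statements on the series, on what has been measured and on what is new or still open speak of the compounds shown alone.

Measured in an ADME assay on cells (Hepatocyte, Homo sapiens) for metabolic stability; a higher number here means faster removal of the compound, a lower number slower removal:
- compound 1 `COCc1cc(-c2cnn(C)c2-c2sc3ccccc3c2C#N)cc2c(CN)n[nH]c(=O)c12`: 66 mL/min/kg
- compound 2 `Cn1ncc(-c2cc(O)c3c(=O)[nH]nc(CN)c3c2)c1-c1sc2ccccc2c1C#N`: < 18 mL/min/kg (a limit, not a number)

Compound 2 stands at the limit of < 18 mL/min/kg in this assay, at which 1 of the 2 values shown sits, so it has a limit and no exact number. The next compound, compound 3 `Cc1cc(-c2cnn(C)c2-c2sc3ccccc3c2C#N)cc2c(CN)n[nH]c(=O)c12`, carries methyl in place of hydroxy on an aromatic carbon. Among the compounds with values here, only one measured step involves this same carbon: an at least 3.6-fold lower number from compound 1 to compound 2 (0.56 log units; beyond the scatter), where hydroxy took the place of methoxymethyl. Compound 3 also loses the hydroxy, so a change in the opposite direction is expected from that step, an at least 3.6-fold lower number from compound 1 to compound 2 (0.56 log units; beyond the scatter), meaning a higher number in this assay. Its size is uncertain, since methyl is not methoxymethyl and the starting point is a limit. The expected change is an at least 1.9-fold higher number from compound 2 to compound 3 (0.28 log units; that floor lies within the scatter). The estimate for compound 3 is 35 mL/min/kg, with an expected range from 16 mL/min/kg to 70 mL/min/kg.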

Compound 3, clearance: 27 mL/min/kg
Estimate against measurement, compound 3: 1.3-fold (0.11 log units) above; measured number inside the range.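

In this assay, replacing only the methoxy of the methoxymethyl group with hydrogen gives a 2.4-fold lower number from compound 1 to compound 3 (0.39 log units; beyond the scatter), so a lower number at this aromatic carbon does not require the hydroxy. Methyl in place of hydroxy gives an at least 1.5-fold higher number from compound 2 to compound 3 (0.17 log units; that floor lies within the scatter), and because that floor lies within the usual scatter, these figures do not establish a real difference between the two groups. The value of compound 2 is a limit and not a number, so the true size of this step remains unknown: the limit of < 18 mL/min/kg in this assay, at which 1 of the 3 values shown sits.

From the compounds shown here alone, it remains open whether hydroxy truly gives slower removal than methyl. Going by these compounds, it is also open how an amine, a fluorine atom or a longer chain such as ethyl on this carbon would behave in this assay.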